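The source may report more compounds than this note shows. Statements on the series, on what has been measured and on what is new or still open speak of the compounds shown alone.

Compound 1 `COc1ccc(C2=NN(c3ccccc3)C(c3ccc(C)cc3)C2S(=O)(=O)CC2=NCCO2)cc1` gives 67.7% in a functional assay, tested at 100 ug/mL; on this read-out lower numbers stand for a weaker effect and higher numbers for a stronger effect at the one concentration tested; compound 2 `COc1ccc(C2=NN(c3ccccc3)C(c3ccc(C)cc3)C2S(=O)(=O)CC2=NCCS2)cc1` gives 47.9% in this assay; compound 3 `O=S(=O)(CC1=NCCS1)c1c(-c2ccccc2)noc1-c1ccccc1` gives "not active" (no number reported) in this assay, with no number given.

Compounds 1 and 2 share one core; compound 3 has a different core, and the difference between the two cores is not broken down here. Within the first core, the step of a number 19.8 percentage points higher from compound 2 to compound 1 (beyond the scatter) is a group of 5 heavy atoms (3 carbon, 1 nitrogen, 1 oxygen; one five-membered non-aromatic ring with 2 hetero atoms) in place of a group of 5 heavy atoms (3 carbon, 1 nitrogen, 1 sulfur; one five-membered non-aromatic ring with 2 hetero atoms), on a saturated chain carbon bound to a sulfonyl sulfur. Compound 4 `O=S(=O)(CC1=NCCO1)c1c(-c2ccccc2)noc1-c1ccccc1` is the unmeasured partner of compound 3, and a group of 5 heavy atoms (3 carbon, 1 nitrogen, 1 oxygen; one five-membered non-aromatic ring with 2 hetero atoms) in place of a group of 5 heavy atoms (3 carbon, 1 nitrogen, 1 sulfur; one five-membered non-aromatic ring with 2 hetero atoms), on a saturated chain carbon bound to a sulfonyl sulfur is the same kind of change. Going by these compounds, whether the core of compound 3 answers that change as the core of compound 2 did is unknown, and compound 3 gives no number to build on. Compound 4 is therefore expected to stay weak, estimated at 15%, plausibly between 0% and 40%.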

Compound 4, a percentage reported as activity, at one concentration (the size of the read-out at that concentration, not a potency): 60.1%
Estimate against measurement, compound 4: 45.1 percentage points below, and the stated range ends below it.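

For the compounds shown here, compound 3 has no number in this assay, so no step to compound 4 can be read. No measured evidence accounts for the result of compound 4. Open, going by these compounds, is how much swapping the sulfur-containing ring for the oxygen-containing one shifts activity on this core.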